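Swapping 2-methylphenyl for pyridin-2-yl: an expected outcome

The source may report more compounds than this note shows. Statements on the series, on what has been measured and on what is new or still open speak of the compounds shown alone.

Measured in a functional assay on HCT-15 cells (Homo sapiens) for cytotoxicity, read by ELISA, with a stated time of 4 days; a higher number here means a weaker inhibitor, a lower number a stronger inhibitor:
compound 1 `Cc1ccsc1-c1cc(-c2ccco2)cc(-c2ccc(Cl)cc2)n1`: 710 nM
compound 2 `Cc1ccsc1-c1cc(-c2ccoc2)cc(-c2ccc(Cl)cc2)n1`: 2990 nM
compound 3 `Cc1ccccc1-c1cc(-c2ccoc2)cc(-c2ccc(Cl)s2)n1`: 990 nM

Compound 3 lies within the scatter of compound 1, and its number is clearly lower than that of compound 2. Compound 4 `Clc1ccc(-c2cc(-c3ccoc3)cc(-c3ccccn3)n2)s1` has pyridin-2-yl in place of 2-methylphenyl on an aromatic carbon. Among the compounds with values here, no measured step involves either group. Within the data shown here, the only measured step, a 4.2-fold higher number from compound 1 to compound 2 (0.62 log units; beyond the scatter), exchanges furan-2-yl for furan-3-yl, so it shows only that one swap can matter. No direction can be drawn from it, so no step beyond the scatter is expected in this assay. The expected step is a 1.2-fold lower number from compound 3 to compound 4 (0.09 log units; within the scatter). Compound 4 is estimated at 800 nM, with an expected range of 250 nM to 2800 nM.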

Compound 4, half-maximal inhibitory concentration: 1270 nM
The estimate for compound 4 lay 1.6-fold (0.20 log units) below the measured number; low and high end bracket the measured number.
By their numbers in this assay, from the lowest: compounds 1, 3 and 4 (each within the scatter of the next); then compound 2.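

In this assay, the exchange of 2-methylphenyl for pyridin-2-yl, next to the ring nitrogen, gives a 1.3-fold higher number from compound 3 to compound 4 (0.11 log units; within the scatter). Within the data shown here, this is the first look at this position, and the two groups cannot be told apart here, even though the ring differs in a nitrogen and the methyl group is gone. No measurement available explains this result. Still open, on these data alone, is whether the methyl group and the ring nitrogen each leave the number unchanged or merely offset each other. A plain phenyl group here would separate the two, and an amine on the ring would test a different kind of group.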